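Piperidin-1-yl for iodo: what compound 4 might show

A few compounds are considered here, and "the series" means these few. Any claim that something is new, unique, unknown or untested is made for them only; others in the source may bear on it.

Compound 1 `O=C(/C=C/c1ccc([N+](=O)[O-])o1)c1ccc(I)cc1` was tested in an ADME assay on Vero cells (Chlorocebus sabaeus) for cytotoxicity, read by resazurin assay, with a stated time of 72 h (on this read-out lower numbers stand for higher toxicity in this test and higher numbers for lower toxicity in this test), and returned only a limit, > 100000 nM, rather than a number. Compound 3 `COc1ccc(/C=C/C(=O)c2cccc(I)c2)cc1` likewise returned only a limit in this assay, namely > 100000 nM. For the measured compounds named here, compound 2 `Cc1cccc(C(=O)/C=C/c2ccc([N+](=O)[O-])o2)c1` is the one member of the set with a measured number, giving 55100 nM in this assay. Going by the values given here, compound 1 therefore stands at the limit of > 100000 nM in this assay, at which 2 of the 3 values shown sit, and no step between it and another measured compound can be drawn from these numbers.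

Compound 4 `O=C(/C=C/c1ccc([N+](=O)[O-])o1)c1ccc(N2CCCCC2)cc1` differs from compound 1 in a single place: piperidin-1-yl in place of iodo on an aromatic carbon. Among the compounds with values here, no measured pair shows what such an exchange does in this assay, and the limit for compound 1 leaves its own position open. In expectation the step of an at least 1.4-fold lower number from compound 1 to compound 4 (0.15 log units; that floor lies within the scatter) is small, if anything, and its direction is not fixed by the data shown. Compound 4 is accordingly estimated at 70000 nM in this assay, within a range from 20000 nM to 200000 nM, and it may well again come back only as a limit.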

Compound 4, half-maximal cytotoxic concentration: 349000 nM
Beside the measured number, compound 4's estimate is 5.0-fold (0.70 log units) below it, outside the stated range (above it).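

For the compounds shown here, no step from compound 1 to compound 4 can be read in this assay, because compound 1 returned only a limit: the limit of > 100000 nM in this assay, at which 2 of the 4 values shown sit.

The compounds shown leave open how large a change piperidin-1-yl in place of iodo on an aromatic carbon brings in this assay, and in which direction.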